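The compounds below may be only part of what the source reports. "The series", "measured", "known", "first", "only" and "open" are said of these compounds alone.

Three analogues of one shared core have been measured in an assay on isolated protein (Cavia porcellus) with Sigma non-opioid intracellular receptor 1 (Homo sapiens) as the target, read by radioligand binding; a higher number here means a weaker inhibitor, a lower number a stronger inhibitor. Compound 1 `CN(C)CCCCCCOc1ccc2oc(-c3ccccc3)cc(=O)c2c1` gives 432 nM, compound 2 `CN(C)CCCCCCCOc1ccc2oc(-c3ccccc3)cc(=O)c2c1` gives 165 nM, and compound 3 `CN(CCCCCCOc1ccc2oc(-c3ccccc3)cc(=O)c2c1)Cc1ccccc1` gives 52 nM. Compound 3 thus holds the lowest number of the three; the nearest is compound 2 and the furthest is compound 1. The step of an 8.3-fold lower number from compound 1 to compound 3 (0.92 log units; beyond the scatter) is the largest seen, while a 2.6-fold lower number from compound 1 to compound 2 (0.42 log units; beyond the scatter) and a 3.2-fold lower number from compound 2 to compound 3 (0.50 log units; beyond the scatter) are smaller.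

Compound 4 `CCN(CC)CCCCCCOc1ccc2oc(-c3ccccc3)cc(=O)c2c1` has not yet been measured. It differs from compound 3 in one place: diethylamino in place of benzyl(methyl)amino on a saturated chain carbon, six bonds along the chain from an oxygen on an aromatic ring. The step that bears most directly on this change is an 8.3-fold lower number from compound 1 to compound 3 (0.92 log units; beyond the scatter), which shows the size gained when phenyl replaced hydrogen on the carbon bound to the amine nitrogen; compound 4 gives that phenyl back up while taking on diethylamino. The step of a 2.6-fold lower number from compound 1 to compound 2 (0.42 log units; beyond the scatter) shows that a small addition of carbon elsewhere on the chain moved the number only modestly. A higher number than compound 3 is therefore expected, without fully returning to compound 1, because an 8.3-fold lower number from compound 1 to compound 3 (0.92 log units; beyond the scatter) outweighs a 2.6-fold lower number from compound 1 to compound 2 (0.42 log units; beyond the scatter). For compound 4 the expected step is a 4.2-fold higher number from compound 3 to compound 4 (0.63 log units; beyond the scatter). The estimated value for compound 4 in this assay is 220 nM, with a range from 90 nM to 550 nM.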

Compound 4, half-maximal inhibitory concentration: 91 nM
Estimate against measurement, compound 4: 2.4-fold (0.38 log units) above, within the range that was stated.
By their numbers in this assay, from the lowest: compounds 3, 4 and 2 (each within the scatter of the next, the first and the last beyond it); then compound 1.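

In this assay the step of a 1.8-fold higher number from compound 3 to compound 4 (0.24 log units; within the scatter) shows that, on a saturated chain carbon, six bonds along the chain from an oxygen on an aromatic ring, diethylamino cannot be told apart from benzyl(methyl)amino, even though the entering group has no ring and fewer heavy atoms. The earlier compounds showed a gain only with the phenyl of compound 3, whereas the step of a 4.7-fold lower number from compound 1 to compound 4 (0.68 log units; beyond the scatter) shows that replacing dimethylamino with diethylamino also gives a change beyond the scatter, so among these compounds an aromatic ring on the amine is not required for it. The step of a 1.8-fold lower number from compound 2 to compound 4 (0.26 log units; within the scatter) places compound 4 within the scatter of compound 2 as well, which leaves diethylamino on the shorter chain and (dimethylamino)methyl at this position unresolved from each other.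

The compounds shown leave open how a ring amine such as piperidine or morpholine would read at this position, and whether diethylamino or benzyl(methyl)amino on a longer chain would move the number further. Nothing given here accounts for why these amine groups read as they do.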